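A Nitro Group Replaces Chlorine on the Benzyl Arm

The source may hold more compounds than are shown below. What is called first, only, known or untested is meant among the compounds shown, and "the series" means these compounds.

Of the compounds shown here, three sharing one core have been measured in an assay on isolated protein for inhibition of Amine oxidase [flavin-containing] A (Homo sapiens), read by fluorescence, with stated times of 15 min and 20 min; a higher number here means a weaker inhibitor, a lower number a stronger inhibitor. Compound 1 `CC(C)(C)c1cc(/C=C/C(=O)NCCC2CCN(Cc3ccccc3)CC2)cc(C(C)(C)C)c1O` gives 62300 nM. Compound 2 `CC(C)(C)c1cc(/C=C/C(=O)NCCC2CCN(Cc3ccc(F)cc3)CC2)cc(C(C)(C)C)c1O`, with fluoro in place of hydrogen on an aromatic carbon, gives 59600 nM, a change described by a 1.0-fold lower number from compound 1 to compound 2 (0.02 log units; within the scatter). Compound 3 `CC(C)(C)c1cc(/C=C/C(=O)NCCC2CCN(Cc3ccccc3Cl)CC2)cc(C(C)(C)C)c1O` gives 72100 nM, the highest of the three numbers, though its gaps to the others, a 1.2-fold higher number from compound 1 to compound 3 (0.06 log units; within the scatter) and a 1.2-fold higher number from compound 2 to compound 3 (0.08 log units; within the scatter), both fall within the scatter, so the three compounds cannot be told apart on these data.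

Compound 4 `CC(C)(C)c1cc(/C=C/C(=O)NCCC2CCN(Cc3cccc([N+](=O)[O-])c3)CC2)cc(C(C)(C)C)c1O` has not yet been measured. It differs from compound 3 by 3-nitrophenyl in place of 2-chlorophenyl on a saturated chain carbon bound to an amine nitrogen in a ring. The measured steps that bear on this change are the two substitutions on the same aromatic ring, a 1.2-fold higher number from compound 1 to compound 3 (0.06 log units; within the scatter) and a 1.2-fold higher number from compound 2 to compound 3 (0.08 log units; within the scatter), neither of which moved the number beyond the scatter. Compound 4 is therefore expected to give about 65000 nM in this assay, within 30000 nM to 140000 nM. The expected step, a 1.1-fold lower number from compound 3 to compound 4 (0.05 log units; within the scatter), stays within the scatter.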

Compound 4, half-maximal inhibitory concentration: 70900 nM
For compound 4 the middle estimate is 1.1-fold (0.04 log units) below the measured one; the range from low to high includes it.
By their numbers in this assay, from the lowest: compounds 2, 1, 4 and 3 (each within the scatter of the next).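

In this assay, exchanging 2-chlorophenyl for 3-nitrophenyl, which brings hydrogen-bond acceptors that 2-chlorophenyl lacks, gives a 1.0-fold lower number from compound 3 to compound 4 (0.01 log units; within the scatter) as its step. The other two comparisons agree, with a 1.2-fold higher number from compound 2 to compound 4 (0.08 log units; within the scatter) for the exchange of 4-fluorophenyl and a 1.1-fold higher number from compound 1 to compound 4 (0.06 log units; within the scatter) for nitro in place of hydrogen, so nitro joins fluoro and chloro among the substituents on this benzyl arm that leave the four compounds indistinguishable. Nothing available here offers an explanation for this flat response.

From the compounds shown here alone, whether an amine or a carboxylic acid on the benzyl arm would carry the number beyond the scatter remains open. Also open, going by these compounds, is what a longer chain between the ring nitrogen and the aromatic ring would do, since all four compounds keep the same benzyl link.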